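The compounds below may be only part of what the source reports. "The series", "measured", "known", "first", "only" and "open" are said of these compounds alone.

Values in a physicochemical assay for lipophilicity, read by HPLC, in phosphate buffer, measured as octanol-water partition, at pH 7.4, tested at 100 uM; a higher number here means a more lipophilic compound, a lower number a more polar compound:
compound 1 `CCOc1cc(C)c(-c2cccc(CNc3ccc(OCC(=O)O)c(F)c3)c2)c(C)c1`: 3.04
compound 2 `O=C(O)COc1ccc(NCc2cccc(-c3ccccc3)c2)cc1F`: 2.25
compound 3 `N#Cc1ccccc1-c1cccc(CNc2ccc(OCC(=O)O)c(F)c2)c1`: "not determined" (no result reported)

Compound 3 has no number to stand on, since its entry in this assay reads "not determined" (no result reported) and no result was reported. Its place relative to the other two compounds therefore cannot be read from the data. The compound that follows it is compound 4 `CCOc1ccc(-c2cccc(CNc3ccc(OCC(=O)O)c(F)c3)c2)c(C)c1`, which has not yet been measured. The structural change is 4-ethoxy-2-methylphenyl in place of 2-cyanophenyl on an aromatic carbon and amounts to 4-ethoxy-2-methylphenyl in place of 2-cyanophenyl on an aromatic carbon, meta to a large group.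

With no starting value, the size of this step can only be loosely expected. A moderate upward step in this assay is the expectation. Among the measured compounds shown here, it rests on the span between compound 2 at 2.25 and compound 1 at 3.04 as the only numbers available, with compound 4 expected in the upper part of that span. Compound 4 is estimated at 2.8 with 2.4 to 3.2 as the expected range.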

Compound 4, distribution coefficient: 2.83
The estimate for compound 4 lay 0.03 log units below the measured number; low and high end bracket the measured number.
By their numbers in this assay, from the lowest: compound 2; then compounds 4 and 1 (each within the scatter of the next).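

On this aromatic carbon, 4-ethoxy-2-methylphenyl in place of phenyl gives in this assay a number 0.58 log units higher from compound 2 to compound 4 (beyond the scatter) and so the substituted ring separates from the bare phenyl, while hydrogen in place of methyl on an aromatic carbon gives a number 0.21 log units lower from compound 1 to compound 4 (within the scatter) and so the extra methyl does not separate the two compounds that carry the ethoxy group. The step from compound 3 to compound 4 cannot be read, for compound 3 has no number. No measurement at hand accounts for either step.

As far as these compounds go, whether the ethoxy group or the remaining methyl carries the step from the bare phenyl stays open. Also open, from the compounds shown here alone, is how a longer chain such as propoxy, or an amine, in place of the ethoxy group would move the number.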